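The source may hold more compounds than are shown below. What is called first, only, known or untested is meant among the compounds shown, and "the series" means these compounds.

Measured in a functional assay on MCF7 cells (Homo sapiens) for cytotoxicity, read by MTT assay, with a stated time of 24 h; a lower number here means a stronger inhibitor, a higher number a weaker inhibitor:
- Compound 1 `O=c1nc2ccc(Br)cn2cc1Cc1ccccc1`: > 1000000 nM (a limit of the assay, not a number)
- Compound 2 `O=c1nc2ccccn2cc1Cc1ccc(F)cc1`: 200000 nM
- Compound 3 `O=c1nc2ccccn2cc1Cc1ccccc1`: 75400 nM

Among the values that are true numbers, compound 3 stands lowest, which makes it the strongest inhibitor of this small set. Its nearest neighbour is compound 2. The next compound, compound 4 `O=c1nc2ccccn2cc1Cc1cccc(Oc2ccccc2)c1`, has phenoxy in place of hydrogen on an aromatic carbon of a six-membered aromatic ring of carbon only, meta to a large group (phenoxy in place of hydrogen on an aromatic carbon).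

For the measured compounds named here, two measured steps bear on this change. Swapping fluoro for hydrogen gave a 2.7-fold lower number from compound 2 to compound 3 (0.42 log units; beyond the scatter), a modest step, and swapping bromo for hydrogen gave an at least 13-fold lower number from compound 1 to compound 3 (1.12 log units; beyond the scatter), a large one. Read backwards, both show a number rising when a group replaces hydrogen on compound 3, though neither group resembles phenoxy closely. A higher number, meaning a weaker inhibitor, is therefore expected in this assay, and the size is expected to be modest to large. The expected step is a 2.7-fold higher number from compound 3 to compound 4 (0.42 log units; beyond the scatter). Compound 4 is estimated at 200000 nM, with an expected range from 60000 nM to 800000 nM.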

Compound 4, half-maximal inhibitory concentration: 243000 nM
Compound 4: middle estimate off by 1.2-fold (0.08 log units), on the low side; the range from low to high includes it.
By their numbers in this assay, from the lowest: compound 3; then compounds 2 and 4 (each within the scatter of the next). At a limit, above all of these: compound 1.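

Adding phenoxy, a group of 7 heavy atoms, on an aromatic carbon meta to a large group gives a 3.2-fold higher number from compound 3 to compound 4 (0.51 log units; beyond the scatter) in this assay and still yields a true number, so this place takes a large group with only a modest loss. That step is modest, as is the step between compound 3 and its fluoro analogue, compound 2, so here a much larger group did not bring a much larger rise. Compound 1, with bromo on the shared core, gives only a limit of the assay, not a number: the limit of > 1000000 nM in this assay, at which 1 of the 4 values shown sits.

From the compounds shown here alone, whether any group at this place raises the number, or phenoxy in particular, stays open. An amine or a carboxylic acid at the same place, or phenoxy elsewhere on this ring, would help to separate these readings.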